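Benzylthio triazole phthalimides: cytotoxicity limits before propyl homologue

A few compounds are considered here, and "the series" means these few. Any claim that something is new, unique, unknown or untested is made for them only; others in the source may bear on it.

Measured so far:
compound 1 `Cc1nnc(SCc2ccccc2)n1N1C(=O)c2ccccc2C1=O` — > 200000 nM
compound 2 `CSc1nnc(C)n1N1C(=O)c2ccccc2C1=O` — > 200000 nM

In a functional assay on A549 cells (Homo sapiens) for cytotoxicity, read by MTT assay, with a stated time of 48 h (on this read-out higher numbers stand for weaker inhibition and lower numbers for stronger inhibition), compound 1 gives only a limit of the assay, > 200000 nM. Compound 2 likewise gives only a limit, > 200000 nM. The step that the two limits leave unreadable from compound 1 to compound 2 is therefore not readable, since the limit of > 200000 nM in this assay, at which 2 of the 2 values shown sit, holds both values. Compound 3 `CCCc1nnc(SCc2ccccc2)n1N1C(=O)c2ccccc2C1=O` carries ethyl in place of hydrogen on a saturated chain carbon bound to an aromatic carbon. For the measured compounds named here, no measured step bears on this change, so no direction can be drawn from compound 1 or compound 2. Compound 3 is expected to remain at the limit as well, the step of a number no higher from compound 1 to compound 3 (the limit leaves the size open) estimated as none readable. The estimate for compound 3 is 200000 nM, range 60000 nM to 600000 nM.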

Compound 3, half-maximal inhibitory concentration: > 200000 nM
Compound 3: only a limit was reported (the forecaster's own chance of this, stated with the estimate: 80%); the middle value lies on the limit itself.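

No step can be read from compound 1 to compound 3, as both values are limits: the limit of > 200000 nM in this assay, at which 3 of the 3 values shown sit.

On these data alone, whether methyl to propyl shifts cytotoxicity at all stays open, as does which change, if any, would bring this series to a readable value.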